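Methoxycarbonyl to Carboxy on an Orexin Receptor Ligand

The compounds below may be only part of what the source reports. "The series", "measured", "known", "first", "only" and "open" are said of these compounds alone.

Compound 1 `O=C(O)c1ccc2ccc(C(=O)c3ccccc3)c-2cc1` and compound 2 `CCOc1ccc(-c2cc(C(=O)c3ccccc3)c3ccc(C(=O)OC)ccc2-3)cc1` were both tested in an assay on cells for displacement of a labelled ligand from Orexin receptor type 2 (Homo sapiens), read by scintillation counting, with stated times of 10 min and 90 min, tested at 10 uM; on this read-out lower numbers stand for less inhibition and higher numbers for more inhibition at the one concentration tested (going by the name of the read-out). Compound 1 gives 32.9% in this assay, while compound 2 gives 19.1%, the lower of the two numbers, with a gap that lies beyond the usual scatter. Compound 2 differs from compound 1 in more than one place, so no single structural change can be read from that gap.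

Compound 3 `CCOc1ccc(-c2cc(C(=O)c3ccccc3)c3ccc(C(=O)O)ccc2-3)cc1` is compound 2 carrying one change: hydrogen in place of methyl on an oxygen next to a carbonyl group. Going by the values given here, no measured pair shows this change on its own, so its effect is not known from the compounds at hand. The step expected in this assay is small and slightly upward, a number 7.9 percentage points higher from compound 2 to compound 3 (within the scatter), and may well stay within the scatter. Compound 3 is therefore estimated at 27%, with a range from 8% to 48%.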

Compound 3, a percentage reported as inhibition, at one concentration (the size of the read-out at that concentration, not a potency): -16.9%
Estimate against measurement, compound 3: 43.9 percentage points above; the whole stated range lies above it.
By their numbers in this assay, from the lowest: compound 3; then compound 2; then compound 1.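

Replacing methyl with hydrogen on an oxygen next to a carbonyl group, which turns methoxycarbonyl into carboxy, is far from a neutral change: in this assay it gives a number 36 percentage points lower from compound 2 to compound 3 (beyond the scatter) as the only difference between the two structures. Carboxy does not fix the level by itself, since 4-ethoxyphenyl in place of hydrogen on an aromatic carbon gives a number 49.8 percentage points lower from compound 1 to compound 3 (beyond the scatter) with carboxy present in both compounds. Nothing measured here explains either fall.

As far as these compounds go, it remains open whether a longer ester, such as an ethyl ester, or an amide at this place would keep the higher number of the methoxycarbonyl compound. From the compounds shown here alone, what 4-ethoxyphenyl does without the carboxylic acid also remains unknown from these compounds.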